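Benzyloxy for Butylamino at the Cytotoxicity Ceiling

The compounds below may be only part of what the source reports. "The series", "measured", "known", "first", "only" and "open" are said of these compounds alone.

In an ADME assay on BCBL1 cells (Homo sapiens) for cytotoxicity, with a stated time of 7 days (on this read-out higher numbers stand for lower toxicity in this test and lower numbers for higher toxicity in this test), compound 2 `CCCCNc1nc(N)nc2c1ncn2/C=C1/CC1(CO)CO` gives > 20000 nM, which is a limit of the assay and not a measured number. Compound 1 `Nc1nc(NCc2ccccc2)c2ncn(/C=C3/CC3(CO)CO)c2n1` gives 19900 nM in this assay. Compound 3 `Nc1nc2c(ncn2/C=C2/CC2(CO)CO)c(=O)[nH]1` likewise gives a limit, > 20000 nM. The picture is dominated by the limit of > 20000 nM in this assay, at which 2 of the 3 values shown sit. Going by the values given here, the one measured step, a number no lower from compound 1 to compound 2 (the limit leaves the size open), touches compound 2, but its size cannot be read. Compound 4 `Nc1nc(OCc2ccccc2)c2ncn(/C=C3/CC3(CO)CO)c2n1` differs from compound 2 by benzyloxy in place of butylamino on an aromatic carbon. Among the compounds with values here, no measured step covers a change of this kind, and the values shown span no readable range. Compound 4 is therefore expected to remain near the ceiling, with a number no higher from compound 2 to compound 4 (the limit leaves the size open) amounting to no change beyond the scatter. The estimate for compound 4 in this assay is 20000 nM, between 10000 nM and 40000 nM.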

Compound 4, half-maximal cytotoxic concentration: > 20000 nM
Compound 4 gave a limit, no number; the forecaster's own chance of this, stated with the estimate: 70%; the middle value sits exactly at the limit.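

Benzyloxy on this aromatic carbon leaves compound 4 at a limit in this assay, as butylamino does in compound 2, so the exchange between these two groups cannot be sized. Against benzylamino in compound 1, the oxygen link gives only a direction, a number no lower from compound 1 to compound 4 (the limit leaves the size open), and neither step to compound 4 has a readable size. The read-out offers little room to separate these groups: the limit of > 20000 nM in this assay, at which 3 of the 4 values shown sit.

On these data alone, whether a longer chain or a carboxylic acid on this carbon would give a measured number instead of a limit stays open.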